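From acetyl to methoxycarbonyl on a read-out at its limit

A few compounds are considered here, and "the series" means these few. Any claim that something is new, unique, unknown or untested is made for them only; others in the source may bear on it.

compound 1 (`COC(=O)c1c[nH]c2cc(OCCOc3ccccc3)c(Cl)cc2c1=O`) : > 20000 nM
compound 2 (`CCCCc1cc2c(=O)c(C(=O)OCC)c[nH]c2cc1OCCOc1ccccc1`) : > 20000 nM
compound 3 (`CCCCc1cc2c(=O)c(C(C)=O)c[nH]c2cc1OCCOc1ccccc1`) : "not determined" (no result reported)

In an ADME assay on J774 cells (Mus musculus) for cytotoxicity (on this read-out higher numbers stand for an effect only at larger amounts of compound and lower numbers for an effect already at smaller amounts), compound 3 has the entry "not determined" (no result reported) and so no single number marks its place. Compound 1 gives > 20000 nM as a limit of the assay and not as a number. Compound 2 likewise gives > 20000 nM as a limit and not as a number. All that frames compound 3 is therefore the limit of > 20000 nM in this assay, at which 2 of the 3 values shown sit, and nothing firmer.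

Compound 4 (`CCCCc1cc2c(=O)c(C(=O)OC)c[nH]c2cc1OCCOc1ccccc1`) has not yet been measured. The structural change is methoxy in place of methyl on a carbonyl carbon and in words it is methoxy in place of methyl on a carbonyl carbon, which, cut one bond further out, reads acetyl to methoxycarbonyl. Going by the values given here, no measured pair shows the size of such a change, and compound 3 offers no number to step from. No step beyond the scatter is expected in this assay in either direction, an expectation that rests on compound 1 and compound 2 sitting at the limit of > 20000 nM in this assay, at which 2 of the 3 values shown sit, in both cases. A report of only a limit is the likeliest outcome. For compound 4 the estimated value is 20000 nM with an expected range from 12000 nM to 35000 nM if a number is obtained.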

Compound 4, half-maximal effective concentration: > 20000 nM
Compound 4: no number, only a limit; the forecaster's own chance of this, stated with the estimate: 85%; the middle value sits exactly at the limit.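

The steps from compound 1 and from compound 2 to compound 4 cannot be read, because compound 4, like the other two, gives only a limit and not a number: the limit of > 20000 nM in this assay, at which 3 of the 4 values shown sit.

The compounds shown leave open whether any of these changes shifts the concentration needed for an effect in this assay, and where compound 3 stands.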